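From Nitro to Methylsulfamoyl on the Pendant Phenyl

A few compounds are considered here, and "the series" means these few. Any claim that something is new, unique, unknown or untested is made for them only; others in the source may bear on it.

Compound 1 `CCCS(=O)(=O)Nc1ccc(F)c(C(=O)c2n[nH]c3ncc(-c4cccc(OC)c4)cc23)c1F`: 6.3%
Compound 2 `CCCS(=O)(=O)Nc1ccc(F)c(C(=O)c2n[nH]c3ncc(-c4cccc(N)c4)cc23)c1F`: 1.6%
Compound 3 `CCCS(=O)(=O)Nc1ccc(F)c(C(=O)c2n[nH]c3ncc(-c4ccc([N+](=O)[O-])cc4)cc23)c1F`: 4.2%

In an assay for binding affinity to dual specificity mitogen-activated protein kinase kinase 4 (Homo sapiens), read by KINOMEscan, tested at 100 nM (on this read-out lower numbers stand for a stronger effect and higher numbers for a weaker effect at the one concentration tested), compound 3 gives 4.2%, the second highest of the three numbers; its nearest neighbour is compound 1 and its furthest is compound 2, and both gaps lie within the scatter. Compound 4 `CCCS(=O)(=O)Nc1ccc(F)c(C(=O)c2n[nH]c3ncc(-c4ccc(S(=O)(=O)NC)cc4)cc23)c1F` differs from compound 3 in one place: methylsulfamoyl in place of nitro on an aromatic carbon. Two measured steps alter the same phenyl substituent, a number 2.1 percentage points lower from compound 1 to compound 3 (within the scatter) and a number 2.6 percentage points higher from compound 2 to compound 3 (within the scatter), and each stays within the scatter. On that basis no step beyond the scatter is expected for a number 1.8 percentage points higher from compound 3 to compound 4 (within the scatter), so compound 4 is estimated at 6%, within a range from 1.5% to 20%.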

Compound 4, a percentage reported as activity, at one concentration (the size of the read-out at that concentration, not a potency): 1.2%
The estimate for compound 4 lay 4.8 percentage points above the measured number; measured number outside the range, below it.
By their numbers in this assay, from the lowest: compounds 4, 2, 3 and 1 (each within the scatter of the next).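

In this assay, the larger methylsulfamoyl, which carries a hydrogen-bond donor that nitro lacks, takes the place of nitro with a number 3 percentage points lower from compound 3 to compound 4 (within the scatter). The comparisons with the other two pendant phenyls give a number 0.4 percentage points lower from compound 2 to compound 4 (within the scatter) and a number 5.1 percentage points lower from compound 1 to compound 4 (within the scatter), so all four compounds now lie within the scatter of one another. Nothing at hand gives a reason for this result. As far as these compounds go, it remains open whether a carboxylic acid or a longer chain on the sulfamoyl nitrogen at this position would also stay within the scatter.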